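The compounds below may be only part of what the source reports. "The series", "measured", "known", "first", "only" and "open" are said of these compounds alone.

- compound 1 `Fc1ccc2nc(-c3ccccc3)nc(Nc3ccccc3)c2c1`: > 50000 nM
- compound 2 `COc1ccccc1Nc1nc(-c2cccc(F)c2)nc2ccc(F)cc12`: > 50000 nM

Both compounds were tested in a functional assay on U2OS cells (Homo sapiens) for cytotoxicity, read by MTT assay, with a stated time of 48 h; a lower number here means a stronger inhibitor, a higher number a weaker inhibitor. Compound 1 gives > 50000 nM, which is a limit of the assay and not a number. Compound 2 gives > 50000 nM, which is also a limit. The whole picture so far is therefore (the limit of > 50000 nM in this assay, at which 2 of the 2 values shown sit). Compound 2 has no exact position on the scale, and the two compounds cannot be ranked against each other.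

Compound 3 `Fc1cccc(-c2nc(Nc3cccc(Cl)c3)c3cc(F)ccc3n2)c1` keeps the rest of compound 2 and changes one group: 3-chlorophenyl takes the place of 2-methoxyphenyl on a nitrogen on an aromatic ring (3-chlorophenyl in place of 2-methoxyphenyl on a nitrogen on an aromatic ring). Within the data shown here, no measured step between two compounds exists to show how much such a swap might matter. With only limits in hand, the expectation in this assay is no change beyond the scatter, and any measurable shift would have to be toward lower numbers. The expected size of the step of a number no higher from compound 2 to compound 3 (the limit leaves the size open) is therefore small. The estimated value for compound 3 is 50000 nM, with an expected range of 20000 nM to 100000 nM.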

Compound 3, half-maximal inhibitory concentration: > 50000 nM
Compound 3 was reported as a limit (the forecaster's own chance of this, stated with the estimate: 70%); the middle value sits exactly at the limit.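

Compound 3 gives > 50000 nM in this assay as its result, which is a limit of the assay and not a number. Compound 2 is also reported as a limit, so no step can be read between compound 2 and compound 3. The compounds shown leave open whether any group on the shared core gives an exact value in this assay at all.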